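This account rests on a few compounds, and the source may have more. Where it says the series, first, only, none or still open, it means among the compounds named here.

Three compounds of the shared core have been run in an assay on HEK293 cells for displacement of a labelled ligand from Melanocortin receptor 4 (Homo sapiens); on this read-out higher numbers stand for weaker inhibition and lower numbers for stronger inhibition. Compound 1 `CC(C)C[C@H](N)c1cc(C(F)(F)F)ccc1N1CCN(C(=O)CC(C)C(=O)c2ccc(Cl)cc2)CC1` gives 1100 nM, the highest of the three numbers. Compound 2 `CC(C)C[C@H](N)c1cc(F)ccc1N1CCN(C(=O)C(C)Cc2ccc(Cl)cc2)CC1` gives 390 nM, the nearest to compound 1 and already beyond the scatter. Compound 3 `CC(C)C[C@H](N)c1ccccc1N1CCN(C(=O)[C@H](C)Cc2ccc(Cl)cc2Cl)CC1` gives 16 nM, the furthest from compound 1 by a wide margin. No two of the three differ in a single place, so the spread among them cannot be tied to any one change.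

Compound 4 `CC(C)C[C@H](N)c1cc(C(F)(F)F)ccc1N1CCN(C(=O)CNc2ccccc2)CC1` is not yet measured. Relative to compound 1 the change is anilino in place of 1-((4-chlorophenyl)carbonyl)ethyl on a saturated chain carbon bound to a carbonyl carbon. The 1-((4-chlorophenyl)carbonyl)ethyl group leaves entirely, and the anilino group that enters is smaller and carries a hydrogen-bond donor where none stood before. For the measured compounds named here, no measured pair shows this change, so its size is open. Because compound 1 already stands at 1100 nM, the weakest end of what has been seen, and the change removes the only chlorinated ring on the amide side, the expectation is a step of a 2.3-fold higher number from compound 1 to compound 4 (0.36 log units; beyond the scatter) toward a weaker number, with wide uncertainty in both directions. Compound 4 is therefore estimated at 2500 nM, within 600 nM to 10000 nM.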

Compound 4, inhibition constant: 3600 nM
Compound 4: middle estimate off by 1.4-fold (0.16 log units), on the low side; low and high end bracket the measured number.
By their numbers in this assay, from the lowest: compound 3; then compound 2; then compound 1; then compound 4.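

In this assay, for the compounds shown here, the replacement of 1-((4-chlorophenyl)carbonyl)ethyl by anilino on a saturated chain carbon bound to a carbonyl carbon gives the first reading of a single change: a 3.3-fold higher number from compound 1 to compound 4 (0.51 log units; beyond the scatter), a modest step. This position therefore responds to a change on the amide side while the rest of the core of compound 1 stays fixed, and since one six-membered aromatic ring of carbon only both leaves and enters, the presence of such a ring here does not by itself keep the number where it was. No supporting data separate the parts of this change, namely the loss of the chlorine, the loss of the carbonyl, the smaller group and the entering hydrogen-bond donor.

Still open, from the compounds shown here alone, is how much of the step belongs to the chlorine, which a chloroanilino group at the same place would help to separate from the other parts of the change. Going by these compounds, it is also open whether the nitrogen of anilino matters, which phenoxy at this place would test, and whether a longer chain such as 2-phenylethylamino would move the number in either direction.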